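The source may hold more compounds than are shown below. What is called first, only, known or untested is meant among the compounds shown, and "the series" means these compounds.

Working notes on the series in an ADME assay on microsomes from liver (Mus musculus) for metabolic stability, using NADPH, with a stated time of 10 min; on this read-out lower numbers stand for a less stable compound and higher numbers for a more stable compound. Of the compounds shown here, three have values so far. Compound 1 `NCCCCN(C[C@@H]1Cc2cccnc2CN1)[C@H]1CCCc2cccnc21` gives 25%, compound 2 `CN(C[C@@H]1Cc2ncccc2CN1)[C@H]1CCCc2cccnc21` gives 0%, and compound 3 `NC/C=C\CN(C[C@H]1Cc2ncccc2CN1)[C@H]1CCCc2cccnc21` gives 37%. Compound 3 stands highest of the three, and its gaps to compound 1 and compound 2 both lie beyond the usual scatter. Among the compounds with values here, no two measured compounds differ in one place only, so no measured step is available to size the next change.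

Compound 4 `CCN(CC)CCCCN(C[C@H]1Cc2ncccc2CN1)[C@H]1CCCc2cccnc21` is next. Its difference from compound 3 is 3-(diethylamino)propyl in place of 3-aminoprop-1-en-1-yl on a saturated chain carbon bound to an amine nitrogen. Read one bond further out, this is 4-aminobut-2-en-1-yl to 4-(diethylamino)butyl.

The closest reference is compound 1, whose chain has no double bond, at 25%. Its core differs from that of compound 3, so it is only a loose guide. A moderate fall beyond the scatter is expected, with the estimated step of a number 19 percentage points lower from compound 3 to compound 4 (beyond the scatter) in this assay. The estimate for compound 4 is 18%, with an expected range of 3% to 38%.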

Compound 4, percent of the compound remaining: 1%
Compound 4: the middle estimate sits 17 percentage points above what was measured; the whole stated range lies above it.
By their numbers in this assay, from the lowest: compounds 2 and 4 (each within the scatter of the next); then compound 1; then compound 3.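

In this assay, within the data shown here, 3-(diethylamino)propyl in place of 3-aminoprop-1-en-1-yl on a saturated chain carbon bound to an amine nitrogen gives a number 36 percentage points lower from compound 3 to compound 4 (beyond the scatter), the only step that can be read so far. This shows that the read-out at this position depends strongly on the side chain, at least on the core of compound 3. The change alters the double bond, the substitution on the terminal nitrogen and the heavy-atom count (4 to 8) together, and no measurement available bears on the reason for the size of the step.

A 4-aminobutyl or a 4-(diethylamino)but-2-en-1-yl chain on the core of compound 3 would separate the double bond from the ethyl groups on the nitrogen. From the compounds shown here alone, whether the step carries over to the core of compound 1 remains open.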